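Compound 3: 3,4-difluorophenyl for 2,5-difluorophenyl

The compounds below may be only part of what the source reports. "The series", "measured", "known", "first", "only" and "open" are said of these compounds alone.

Compound 1 `O=C1c2ccccc2C(=O)N1CCOC(=S)N(C(=O)c1ccc(C(F)(F)F)cc1)c1ccc(Cl)cc1` gives 10000 nM
Compound 2 `O=C1c2ccccc2C(=O)N1CCOC(=S)N(C(=O)c1cc(F)ccc1F)c1ccc(Cl)cc1` gives 54000 nM

These two values come from an ADME assay on MT4 cells (Homo sapiens) for cytotoxicity, read by MTT assay (a higher number here means that more compound is tolerated, a lower number that less compound is tolerated), where compound 2 holds the higher number. Compound 3 `O=C1c2ccccc2C(=O)N1CCOC(=S)N(C(=O)c1ccc(F)c(F)c1)c1ccc(Cl)cc1` has not yet been measured. It differs from compound 2 as follows: 3,4-difluorophenyl in place of 2,5-difluorophenyl on a carbonyl carbon. In words, 3,4-difluorophenyl stands in place of 2,5-difluorophenyl on a carbonyl carbon.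

Among the measured compounds shown here, only one measured step bears on this change: a 5.4-fold higher number from compound 1 to compound 2 (0.73 log units; beyond the scatter). For the measured compounds named here, that step exchanged a different group, so no measured pair isolates the placement of the fluorines, and its size is only a rough guide. With compound 2 at 54000 nM, the higher of just two values, a small drop is expected, probably not beyond the scatter. The expected step is a 1.8-fold lower number from compound 2 to compound 3 (0.26 log units; within the scatter). Compound 3 is estimated at 30000 nM, with an expected range from 12000 nM to 75000 nM.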

Compound 3, half-maximal cytotoxic concentration: 52000 nM
Compound 3: middle estimate off by 1.7-fold (0.24 log units), on the low side; low and high end bracket the measured number.
By their numbers in this assay, from the lowest: compound 1; then compounds 3 and 2 (each within the scatter of the next).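

In this assay, moving the two fluorines from the 2,5-difluorophenyl to the 3,4-difluorophenyl arrangement on the carbonyl carbon gives a 1.0-fold lower number from compound 2 to compound 3 (0.02 log units; within the scatter), so among these compounds the placement of the fluorines does not separate the two isomers. Replacing the 4-(trifluoromethyl)phenyl with 3,4-difluorophenyl gives a 5.2-fold higher number from compound 1 to compound 3 (0.72 log units; beyond the scatter), which shows that the gap first seen with compound 2 is not confined to one difluorophenyl arrangement: both compound 2 and compound 3 stand clear of compound 1. No measured evidence accompanies these compounds to explain this result.

The compounds shown leave open whether an unsubstituted phenyl or a monofluorophenyl on this carbonyl carbon would fall with compound 2 and compound 3 or with compound 1. They also leave open where a methoxyphenyl or a pyridine would fall in this assay.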